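A Methoxy Turns Hydroxy in a Flat Series

The source may report more compounds than this note shows. Statements on the series, on what has been measured and on what is new or still open speak of the compounds shown alone.

In a functional assay on MDA-MB-231 cells (Homo sapiens) for cytotoxicity, with a stated time of 48 h (on this read-out lower numbers stand for stronger inhibition and higher numbers for weaker inhibition), compound 1 `COc1cc(OC)c(C(=O)/C=C/c2ccccc2OC)c(OC)c1` gives 13000 nM. Compound 2 `COc1cc(OC)c(C(=O)/C=C/c2ccccc2SC)c(OC)c1` gives 9900 nM, and compound 3 `COc1cc(OC)c(C(=O)/C=C/c2ccccc2)c(OC)c1` gives 12900 nM. These three numbers lie within the scatter of one another, so compound 1 cannot be ranked against the other two.

The next compound, compound 4 `COc1cc(O)c(C(=O)/C=C/c2ccccc2OC)c(OC)c1`, differs from compound 1 in one place: hydrogen in place of methyl on an oxygen on an aromatic ring. This is hydrogen in place of methyl on an oxygen on an aromatic ring, which turns a methoxy into a hydroxy.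

The measured steps bear on this change only indirectly. A different methoxy group of compound 1 has been changed twice, giving a 1.3-fold lower number from compound 1 to compound 2 (0.12 log units; within the scatter) with methylsulfanyl and a 1.0-fold lower number from compound 1 to compound 3 (0.00 log units; within the scatter) with hydrogen, and these small steps suggest that no large move should be expected here. Among the compounds with values here, no measured compound carries a hydroxy, so the series offers no direct precedent and the range has to stay wide.

In this assay, the expected change is a 1.3-fold lower number from compound 1 to compound 4 (0.11 log units; within the scatter), a step not expected to go beyond the scatter in either direction. For compound 4 the estimated value is 10000 nM, with an expected range from 4000 nM to 25000 nM.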

Compound 4, half-maximal inhibitory concentration: > 20000 nM
Compound 4: a limit, no number; the forecaster's own chance of this, stated with the estimate: 4%; at least 2.0-fold (0.30 log units) between middle value and limit.
By their numbers in this assay, from the lowest: compounds 2, 3 and 1 (each within the scatter of the next). At a limit, above all of these: compound 4.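

The result for compound 4 in this assay is a limit of the assay, not a number. Hydrogen in place of methyl on this oxygen gives an at least 1.5-fold higher number from compound 1 to compound 4 (0.18 log units; that floor lies within the scatter), so the hydroxy of compound 4 shows no sign of a lower number, yet the true size of the step is unknown and its floor alone does not separate the two compounds. The earlier steps shown here, made at a different methoxy, all came with a measured size, whereas this first change at this methoxy has an open upper end, and the series now holds a single compound at that limit: the limit of > 20000 nM in this assay, at which 1 of the 4 values shown sits.

The compounds shown leave open whether a longer chain, such as ethyl, on this oxygen or an amine in place of the hydroxy would read like compound 1 or like compound 4. Within the data shown here, they also leave open how a hydroxy would read at the other methoxy, the one exchanged in compound 2 and compound 3, and so whether the result for compound 4 belongs to this oxygen alone.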